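The source may hold more compounds than are shown below. What is called first, only, known or untested is meant among the compounds shown, and "the series" means these compounds.

Within the data shown here, compound 1 `C=CC(=O)N1C(=O)CC(c2ccc(OC)cc2)Sc2ccccc21` gives 92100 nM in a functional assay on HL-60 cells (Homo sapiens) for cytotoxicity, read by CCK-8 assay, with a stated time of 24 h (on this read-out higher numbers stand for weaker inhibition and lower numbers for stronger inhibition), and compound 2 `C=CC(=O)N1C(=O)CC(c2ccc(Br)cc2)Sc2ccccc21` gives 126000 nM on the same read-out, so compound 2 stands within the scatter of its only neighbour. Among the measured compounds shown here, the one measured step, bromo in place of methoxy on an aromatic carbon, is a 1.4-fold higher number from compound 1 to compound 2 (0.14 log units; within the scatter) and does not separate the two compounds. Next is compound 3 `C=CC(=O)N1C(=O)CC(c2ccccc2Cl)Sc2ccccc21` with 2-chlorophenyl in place of 4-bromophenyl on a saturated ring carbon of the shared core. For the measured compounds named here, no measured step covers this exact exchange, so the evidence is thin. With only a 1.4-fold higher number from compound 1 to compound 2 (0.14 log units; within the scatter) as a guide, no step beyond the scatter is expected in this assay for this change. The expected step is a 1.3-fold lower number from compound 2 to compound 3 (0.10 log units; within the scatter) by this estimate. For compound 3 the estimated value is 100000 nM with an expected range of 45000 nM to 220000 nM in these notes.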

Compound 3, half-maximal inhibitory concentration: 91400 nM
Beside the measured number, compound 3's estimate is 1.1-fold (0.04 log units) above it; the range from low to high includes it.
By their numbers in this assay, from the lowest: compounds 3, 1 and 2 (each within the scatter of the next).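

In this assay, exchanging 4-bromophenyl for 2-chlorophenyl on the saturated ring carbon next to the ring sulfur gives a 1.4-fold lower number from compound 2 to compound 3 (0.14 log units; within the scatter), and exchanging 4-methoxyphenyl for 2-chlorophenyl at the same carbon gives a 1.0-fold lower number from compound 1 to compound 3 (0.00 log units; within the scatter). The earlier pair covered only 4-substituted phenyl groups; with a 2-substituted phenyl added, the three compounds still stand within the scatter of each other, so neither the change of substituent nor its place on the phenyl ring separates them here. Nothing on hand offers an explanation for this flat result.

From the compounds shown here alone, it remains open whether a group other than a substituted phenyl at this carbon, such as an aminomethyl group or a carboxylic acid, would produce a step beyond the scatter. Also open, going by these compounds, is how replacing the vinylcarbonyl group on the shared core would affect the number.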